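Moving the Chlorine Around a Pyridine-Based Cytotoxic Scaffold

The compounds below may be only part of what the source reports. "The series", "measured", "known", "first", "only" and "open" are said of these compounds alone.

Within the data shown here, compound 1 `Oc1ccc(-c2cc(-c3ccco3)nc(-c3ccccc3Cl)c2)cc1` is the only compound of this small set with a number behind it. In a functional assay on T47D cells (Homo sapiens) for cytotoxicity, read by CCK-8 assay and cell counting, with a stated time of 2 days (a higher number here means a weaker inhibitor, a lower number a stronger inhibitor), compound 1 gives 5480 nM, a modest potency. A close relative, compound 2 `Oc1ccc(-c2cc(-c3ccccn3)nc(-c3ccccc3Cl)c2)cc1`, was run in the same setting, but in this assay compound 2 gives "not determined" (no result reported), so compound 1 stands alone on the numbers shown.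

Compound 3 `Oc1ccc(-c2cc(-c3ccc(Cl)cc3)nc(-c3ccco3)c2)cc1` keeps every atom of compound 1 but rearranges them: 4-chlorophenyl in place of 2-chlorophenyl on an aromatic carbon. Among the measured compounds shown here, no measured pair in this set shows what such a shift of the chlorine does, so there is no step to lean on. With nothing to point either way, the step from compound 1 to compound 3 in this assay is expected to stay within the usual scatter of repeated measurements, a 1.1-fold lower number from compound 1 to compound 3 (0.04 log units; within the scatter). On that basis compound 3 is estimated at 5000 nM, with a plausible range from 1500 nM to 16000 nM.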

Compound 3, half-maximal inhibitory concentration: 6260 nM
Beside the measured number, compound 3's estimate is 1.3-fold (0.10 log units) below it; the range from low to high includes it.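

In this assay, the 4-chlorophenyl group in place of the 2-chlorophenyl group on this aromatic carbon gives a 1.1-fold higher number from compound 1 to compound 3 (0.06 log units; within the scatter), so the two compounds cannot be told apart on potency. Among these compounds, this is the first measured step in the set, and it shows that, for this pair, relocating the chlorine around the phenyl ring leaves the cytotoxicity reading where it was, at a modest level. Nothing measured here offers an explanation for that outcome.

A different substituent on that phenyl ring, such as an amine or a carboxylic acid in place of the chlorine, could behave differently, and the compounds shown do not tell. What the 4-hydroxyphenyl group contributes also stays open, as it is the same in every compound shown.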